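Halogen plus trifluoromethyl ring in place of methylphenyl

The source may report more compounds than this note shows. Statements on the series, on what has been measured and on what is new or still open speak of the compounds shown alone.

Measured so far in a functional assay on MDA-MB-231 cells (Homo sapiens) for inhibition, read by MTT assay and WST assay, with a stated time of 72 h, tested at 10 uM; on this read-out lower numbers stand for less inhibition of growth and higher numbers for more inhibition of growth at the one concentration tested:
compound 1, `O=C(Nc1ccc(Cl)cc1)Nc1ccc(Oc2ccc(-c3nccs3)cc2)cc1`, gives 32.5%
compound 2, `O=C(Nc1ccc(Oc2ccc(-c3nccs3)cc2)cc1)Nc1ccc(F)c(C(F)(F)F)c1`, gives 71.8%
compound 3, `Cc1ccc(NC(=O)Nc2ccc(Oc3ccc(-c4nccs4)cc3)cc2)cc1`, gives 22.8%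

Compound 3 shows the lowest of the three numbers, though its gap to compound 1, a number 9.7 percentage points lower from compound 1 to compound 3 (within the scatter), is within the scatter, so the two cannot be ranked; only compound 2 stands clearly apart, a number 49 percentage points lower from compound 2 to compound 3 (beyond the scatter).

Compound 4, `O=C(Nc1ccc(Oc2ccc(-c3nccs3)cc2)cc1)Nc1cc(C(F)(F)F)ccc1Cl`, has not yet been measured. It differs from compound 3 in one place: 2-chloro-5-(trifluoromethyl)phenyl in place of 4-methylphenyl on an amide-type nitrogen.

The step that bears on this is the one where a halogen- and trifluoromethyl-bearing ring entered: a number 39.3 percentage points higher from compound 1 to compound 2 (beyond the scatter). Compound 4 carries a ring of that same type, a chlorine together with a trifluoromethyl group, so a large rise in this assay is expected, of the order of a number 39.2 percentage points higher from compound 3 to compound 4 (beyond the scatter). Compound 4 is thus estimated at 62%, with a range from 40% to 80%.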

Compound 4, percent growth inhibition at one concentration: 60.4%
Compound 4: middle estimate off by 1.6 percentage points, on the high side; measured number inside the range.
By their numbers in this assay, from the lowest: compounds 3 and 1 (each within the scatter of the next); then compound 4; then compound 2.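

In this assay, a second ring carrying both a halogen and a trifluoromethyl group also gives a large rise over the methyl-bearing ring (a number 37.6 percentage points higher from compound 3 to compound 4 (beyond the scatter)) and a clear rise over the ring with chlorine alone (a number 27.9 percentage points higher from compound 1 to compound 4 (beyond the scatter)), so the high number of compound 2 is no longer a lone case. The two rings of this type are still not interchangeable on the amide-type nitrogen, as 2-chloro-5-(trifluoromethyl)phenyl in place of 4-fluoro-3-(trifluoromethyl)phenyl gives a modest drop (a number 11.4 percentage points lower from compound 2 to compound 4 (beyond the scatter)). Nothing available explains these differences.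

Compound 1 shows that a chlorine alone does not bring the high numbers, but the compounds shown leave open whether a trifluoromethyl group alone on the phenyl ring would. They also leave open how a ring bearing a nitrile, an amine or a carboxylic acid would behave here.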